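Half-life series: hydroxy to cyano on the sulfonyl pyridine

This account rests on a few compounds, and the source may have more. Where it says the series, first, only, none or still open, it means among the compounds named here.

Measured compounds:
compound 1 `O=C(NCc1ccc(F)cc1)c1ccc(N2CCN(S(=O)(=O)c3cccnc3O)CC2)nn1`: 1.2 h
compound 2 `N#Cc1ncccc1S(=O)(=O)N1CCN(c2ccc(C(=O)NCc3ccc(F)cc3)[n+]([O-])n2)CC1`: 0.267 h
compound 3 `Cc1ccccc1S(=O)(=O)N1CC=C(c2ccc(C(=O)NCc3ccc(F)cc3)nn2)CC1`: 0.0833 h

In an ADME assay on microsomes from liver (Mus musculus) for metabolic stability, read by LC-MS, using NADPH, tested at 10 uM (a higher number here means that the compound lasts longer, a lower number that the compound disappears faster), compound 1 gives the highest of the three half-lives. Its nearest neighbour is compound 2; that gap lies beyond the scatter. The gap to compound 3 is larger still and also beyond the scatter.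

Compound 4 `N#Cc1ncccc1S(=O)(=O)N1CCN(c2ccc(C(=O)NCc3ccc(F)cc3)nn2)CC1` has not been measured. Relative to compound 1 the change is cyano in place of hydroxy on an aromatic carbon. Within the data shown here, no pair of measured compounds differs in this one place alone, so the size of the step can only be expected, not read off. Compound 2 also carries a cyano group and gives a much shorter half-life than compound 1, so the step from compound 1 to compound 4 is expected to be downward, likely beyond the scatter, estimated at a 2.4-fold lower number from compound 1 to compound 4 (0.38 log units; beyond the scatter). For compound 4 the expected half-life is 0.5 h, with a range from 0.2 h to 1.2 h; the lower end is set partly because compound 2 gives 0.267 h.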

Compound 4, half-life: 0.0833 h
The estimate for compound 4 lay 6.0-fold (0.78 log units) above the measured number; the whole stated range lies above it.
By their numbers in this assay, from the lowest: compounds 3 and 4 (each within the scatter of the next); then compound 2; then compound 1.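

In this assay, among these compounds, the change from 2-hydroxypyridin-3-yl to 2-cyanopyridin-3-yl gives the first step that can be read at a single place, a 14-fold lower number from compound 1 to compound 4 (1.16 log units; beyond the scatter), so the group on this aromatic carbon matters greatly for the half-life. The two cyano compounds, which differ in one place, the extra oxygen on the core of compound 2, do not share a value: compound 2 gives 0.267 h and compound 4 gives 0.0833 h. No measurement shown here accounts for the size of the step.

Going by these compounds, it remains open whether the step follows from losing the hydroxy or from gaining the cyano. A methoxy group, an amine or a carboxylic acid on the same carbon could help to separate the two.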